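The source may hold more compounds than are shown below. What is called first, only, known or untested is meant among the compounds shown, and "the series" means these compounds.

Measured so far:
compound 1, `CCOC(=O)c1cnnn1CCOCC1=NC(C)=C(C(=O)OC)C(c2ccccc2Cl)/C1=C(\O)OCC`, in a functional assay (aorta) with Rattus norvegicus as the target (on this read-out lower numbers stand for stronger inhibition and higher numbers for weaker inhibition), compound 1 gives 100 nM
compound 2, `CCO/C(O)=C1\C(COCCn2cc(N)nc2O)=NC(C)=C(C(=O)OC)C1c1ccccc1Cl`, in this assay compound 2 gives 31.6 nM

Among these two numbers compound 2 stands lowest; its only neighbour is compound 1, and the step of a 3.2-fold lower number from compound 1 to compound 2 (0.50 log units; beyond the scatter) puts the two apart by more than the scatter. Compound 3, `CCOC(=O)c1cn(CCOCC2=NC(C)=C(C(=O)OC)C(c3ccccc3Cl)/C2=C(\O)OCC)nn1`, has not yet been measured. It differs from compound 2 in one place: 4-(ethoxycarbonyl)-1H-1,2,3-triazol-1-yl in place of 4-amino-2-hydroxy-1H-imidazol-1-yl on a saturated chain carbon, two bonds along the chain from an oxygen on a saturated carbon. The group that enters is an ethoxycarbonyl-bearing triazolyl of the same kind as the 5-(ethoxycarbonyl)-1H-1,2,3-triazol-1-yl of compound 1, the two names differing only in the number they carry. Among the compounds with values here, the single measured step that bears on this change is a 3.2-fold lower number from compound 1 to compound 2 (0.50 log units; beyond the scatter), which runs the opposite way, from such a triazolyl to the amino-hydroxy-imidazolyl. Reversing it, a modest rise in the number is expected for compound 3, of about a 2.5-fold higher number from compound 2 to compound 3 (0.40 log units; beyond the scatter), landing near where compound 1 already stands. The estimate for compound 3 in this assay is therefore 80 nM, with a range from 30 nM to 250 nM.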

Compound 3, half-maximal inhibitory concentration: 50.1 nM
Compound 3: middle estimate off by 1.6-fold (0.20 log units), on the high side; the measured number falls inside the stated range.
By their numbers in this assay, from the lowest: compounds 2, 3 and 1 (each within the scatter of the next, the first and the last beyond it).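

In this assay, the step of a 1.6-fold higher number from compound 2 to compound 3 (0.20 log units; within the scatter) shows that a triazolyl bearing ethoxycarbonyl on this saturated chain carbon need not stand apart from 4-amino-2-hydroxy-1H-imidazol-1-yl, so the earlier gap of a 3.2-fold lower number from compound 1 to compound 2 (0.50 log units; beyond the scatter) does not hold for every such triazolyl. The two triazolyl groups are not separated from each other either, with a 2.0-fold lower number from compound 1 to compound 3 (0.30 log units; within the scatter) as the step between 5-(ethoxycarbonyl)-1H-1,2,3-triazol-1-yl and 4-(ethoxycarbonyl)-1H-1,2,3-triazol-1-yl, so this position tolerates all three groups within a narrow band in which only compound 1 and compound 2 lie beyond the scatter of each other. Nothing available explains these numbers or links them to any feature of the groups.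

The three compounds leave open whether the ethoxycarbonyl on the triazolyl can give way to a carboxylic acid or a primary amide with the number staying in this band. They also leave open how the number responds to a propyl chain in place of the ethyl chain that carries these rings, or to a simple amine in place of the ring at this position.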